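A few compounds are considered here, and "the series" means these few. Any claim that something is new, unique, unknown or untested is made for them only; others in the source may bear on it.

The measured compounds:
compound 1, `COc1ccc(NC(=O)c2cccc(/C=C3\CC(=O)N(c4ccccc4)C3=O)c2)c(C)c1`, which in an ADME assay on NCM460 cells (Homo sapiens) for cytotoxicity, read by MTT assay, with a stated time of 72 h (a higher number here means a weaker inhibitor, a lower number a stronger inhibitor), gives > 100000 nM, a limit of the assay rather than a number.
compound 2, `COc1cc(NC(=O)c2cccc(/C=C3\CC(=O)N(c4ccccc4)C3=O)c2)cc(OC)c1OC`, which in this assay gives > 100000 nM, again a limit.
compound 3, `O=C(Nc1ccc(Cl)cc1)c1cccc(/C=C2\CC(=O)N(Cc3ccccc3)C2=O)c1`, which in this assay gives > 100000 nM, also a limit.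

Compound 1 stands at the ceiling of what this assay reports, and it shares that position with compound 2 and compound 3: the limit of > 100000 nM in this assay, at which 3 of the 3 values shown sit. None of the three gives a numerical reading, so no measured step between any pair can be sized; all the values show is that none of these compounds registers as an inhibitor in this assay.

The compound not yet measured is compound 4, `O=C(Nc1ccc(Cl)cc1)c1cccc(/C=C2\CC(=O)N(c3ccccc3)C2=O)c1`. It differs from compound 1 in one place: 4-chlorophenyl in place of 4-methoxy-2-methylphenyl on an amide-type nitrogen. Compound 3 also carries a 4-chlorophenyl on its amide-type nitrogen and sits at the same limit. One expects no step beyond the scatter in this assay from compound 1 to compound 4, and expects the reading to come back as a limit once more. The estimate for compound 4 is 100000 nM, with a range from 50000 nM to 200000 nM. That estimate means an expected step of a number no higher from compound 1 to compound 4 (the limit leaves the size open).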

Compound 4, half-maximal inhibitory concentration: > 100000 nM
Compound 4: a limit, no number; the forecaster's own chance of this, stated with the estimate: 85%; the middle value sits exactly at the limit.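

Compound 4 also returns a limit, as do compound 1 and compound 3, so neither of its steps to those two compounds can be read: the limit of > 100000 nM in this assay, at which 4 of the 4 values shown sit. The compounds shown leave open whether any other group on the amide-type nitrogens would give a numerical reading in this assay and how far these four compounds actually differ.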